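The source may report more compounds than this note shows. Statements on the series, on what has been measured and on what is new or still open speak of the compounds shown alone.

Compound 3 `CNC(=O)N1CCCc2ccc(NC(=O)c3cccc(-c4cnn(S(C)(=O)=O)c4)c3)cc21` gives 18% in a functional assay on MV4-11 cells (Homo sapiens) for antiproliferative activity, with a stated time of 6 days, tested at 6.25 uM; on this read-out lower numbers stand for a weaker effect and higher numbers for a stronger effect at the one concentration tested. Among the three compounds measured so far, compound 3 stands second highest. Compound 1 `CNC(=O)N1CCCc2ccc(NC(=O)c3cccc(-c4ccccc4)c3)cc21` gives 1.39%, and the step of a number 16.6 percentage points higher from compound 1 to compound 3 (beyond the scatter). Compound 2 `CNC(=O)N1CCCc2ccc(NC(=O)c3cccc(-c4cc[nH]n4)c3)cc21` gives 89.7%, and the step of a number 71.7 percentage points lower from compound 2 to compound 3 (beyond the scatter). Between the two others, the step of a number 88.3 percentage points higher from compound 1 to compound 2 (beyond the scatter).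

Compound 4 `CNC(=O)N1CCCc2ccc(NC(=O)c3cccc(-c4cnn(C)c4)c3)cc21` is still unmeasured. It differs from compound 3 in one place: methyl in place of methylsulfonyl on an aromatic nitrogen. Among the measured compounds shown here, no measured step exchanges one group for another on an aromatic nitrogen, so nothing mirrors this change exactly. The closest comparison is compound 2, whose ring carries no group on its nitrogen, against compound 3, which carries methylsulfonyl on that nitrogen; that step was large, but it also moved the point at which the ring is attached, so it does not isolate the methylsulfonyl. The expectation is that taking methylsulfonyl away and putting methyl in its place moves the number in this assay upward, by a modest to large step, with wide uncertainty. Compound 4 is therefore estimated at 45%, within a range from 10% to 85%. The step expected is a number 27 percentage points higher from compound 3 to compound 4 (beyond the scatter).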

Compound 4, a percentage reported as inhibition, at one concentration (the size of the read-out at that concentration, not a potency): 93.5%
Estimate against measurement, compound 4: 48.5 percentage points below; measured number above the stated range.
By their numbers in this assay, from the lowest: compound 1; then compound 3; then compounds 2 and 4 (each within the scatter of the next).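

Compound 3 and compound 4 share the same point of ring attachment, so the step of a number 75.5 percentage points higher from compound 3 to compound 4 (beyond the scatter) in this assay isolates what compound 2 against compound 3 could not: the exchange of methylsulfonyl for methyl on the aromatic nitrogen alone accounts for a large change. A group on that nitrogen is also compatible with a high number, since the step of a number 3.8 percentage points higher from compound 2 to compound 4 (within the scatter) shows that methyl there, with the ring attached at a different point, gives a result that cannot be told apart from that of the unsubstituted 1H-pyrazol-3-yl ring. The step of a number 92.1 percentage points higher from compound 1 to compound 4 (beyond the scatter) adds a second pyrazole that stands far from phenyl, which leaves compound 3 as the one pyrazole shown with a low number.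

Nothing given here explains why the methylsulfonyl compound falls so far. Going by these compounds, it remains open whether an ethyl, an acetyl or a longer chain ending in an amine on that nitrogen would keep the high number or lose it, and a reading at one concentration cannot separate the potency of compound 2 from that of compound 4.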